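The compounds below may be only part of what the source reports. "The series", "measured", "known", "first", "only" and "open" are said of these compounds alone.

Measured so far:
compound 1 `COc1ccc(CNCc2c(OC)cc(Oc3cccc(Nc4ccccc4)c3)cc2OC)cc1` — 6970 nM
compound 2 `COc1cc(Oc2cccc(Nc3ccccc3)c2)cc(OC)c1CNCc1ccc(F)cc1` — 6770 nM
compound 3 `COc1cc(Oc2cccc(Nc3ccccc3)c2)cc(OC)c1CNC1CC1` — the limit > 20000 nM

In a functional assay on SW-620 cells (Homo sapiens) for inhibition, read by MTT assay, with a stated time of 72 h (on this read-out higher numbers stand for weaker inhibition and lower numbers for stronger inhibition), compound 1 gives 6970 nM and compound 2 gives 6770 nM. For compound 3 this assay reports only a limit, > 20000 nM. Compound 3 therefore stands at the weak end of the three: an at least 2.8-fold higher number from compound 1 to compound 3 (0.45 log units; beyond the scatter) and an at least 2.9-fold higher number from compound 2 to compound 3 (0.47 log units; beyond the scatter), whereas a 1.0-fold lower number from compound 1 to compound 2 (0.01 log units; within the scatter).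

Compound 4 `COc1cc(Oc2cccc(Nc3ccccc3)c2)cc(OC)c1CNCc1ccc(Br)cc1` differs from compound 3 by 4-bromobenzyl in place of cyclopropyl on an amine nitrogen. This reverses the two benzyl-to-cyclopropyl steps, each of which lost potency beyond the scatter, so a gain of similar size is expected. Because a 1.0-fold lower number from compound 1 to compound 2 (0.01 log units; within the scatter) showed no change between two benzyl variants, a bromobenzyl is expected to land near compound 1 and compound 2. Compound 4 is estimated at 6000 nM, between 2500 nM and 15000 nM, which is expected to mean an at least 3.3-fold lower number from compound 3 to compound 4 (0.52 log units; beyond the scatter).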

Compound 4, half-maximal inhibitory concentration: 11200 nM
Compound 4: the middle estimate sits 1.9-fold (0.27 log units) below what was measured; the measured number falls inside the stated range.
By their numbers in this assay, from the lowest: compounds 2, 1 and 4 (each within the scatter of the next). At a limit, above all of these: compound 3.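

In this assay, the three substituents on the benzyl aromatic carbon cannot be told apart: a 1.7-fold higher number from compound 2 to compound 4 (0.22 log units; within the scatter) and a 1.6-fold higher number from compound 1 to compound 4 (0.21 log units; within the scatter), so bromo joins fluoro and methoxy at this position. The step from the cyclopropyl amine to the 4-bromobenzyl amine reads only as a floor: an at least 1.7-fold lower number from compound 3 to compound 4 (0.25 log units; that floor lies within the scatter). Compound 3 stands at a limit: the limit of > 20000 nM in this assay, at which 1 of the 4 values shown sits.

On these data alone, whether an unsubstituted benzyl or a longer chain such as phenethyl on that amine nitrogen would hold these values stays open. So does the effect of a carboxylic acid or an amine on that aromatic carbon.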